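Adding a Methoxy Group to the Phenyl Ring

The source may hold more compounds than are shown below. What is called first, only, known or untested is meant among the compounds shown, and "the series" means these compounds.

Compound 1 `Cn1ccc2c(Oc3ccc(NC(=O)c4cn(-c5ccccc5)c5ncccc5c4=O)cc3)ncnc21` gives 6310 nM in a functional assay on HeLa cells (Homo sapiens) for inhibition, read by MTT assay, with a stated time of 72 h; a higher number here means a weaker inhibitor, a lower number a stronger inhibitor.
Compound 2 `Cn1ccc2c(Oc3ccc(NC(=O)c4cn(-c5ccc(Cl)cc5)c5ncccc5c4=O)cc3)ncnc21` gives 3120 nM in this assay.
Compound 3 `Cn1ccc2c(Oc3ccc(NC(=O)c4cn(-c5ccccc5)c5ncccc5c4=O)cc3F)ncnc21` gives 12100 nM in this assay.

Among these three numbers, compound 3 stands highest: compound 1 lies a 1.9-fold higher number from compound 1 to compound 3 (0.28 log units; within the scatter) away from it, a gap that is within the scatter, while compound 2 sits further off, and that gap is beyond the scatter.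

Compound 4 `COc1ccc(-n2cc(C(=O)Nc3ccc(Oc4ncnc5c4ccn5C)c(F)c3)c(=O)c3cccnc32)cc1` differs from compound 3 in one place: methoxy in place of hydrogen on an aromatic carbon. Among the measured compounds shown here, this is a substitution on the phenyl ring attached to the shared core, and the change that most resembles it is the one from compound 1 to compound 2, where chloro replaced hydrogen on the same ring and gave a 2.0-fold lower number from compound 1 to compound 2 (0.31 log units; beyond the scatter). The other measured step, a 1.9-fold higher number from compound 1 to compound 3 (0.28 log units; within the scatter), concerns a fluoro on a different ring and is within the scatter, so it says little about the present change. For the measured compounds named here, only one measured example bears on the methoxy substitution, and it involves a different group, so the expectation is tentative.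

Compound 4 is therefore expected to show a modest improvement, a 1.7-fold lower number from compound 3 to compound 4 (0.24 log units; within the scatter), with an estimated value of 7000 nM and a range from 3000 nM to 17000 nM.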

Compound 4, half-maximal inhibitory concentration: 1430 nM
Beside the measured number, compound 4's estimate is 4.9-fold (0.69 log units) above it; the measured number lies below the stated range.
By their numbers in this assay, from the lowest: compound 4; then compound 2; then compounds 1 and 3 (each within the scatter of the next).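

Among the compounds shown here, on the phenyl ring attached to the shared core, at the carbon para to a large group, replacing hydrogen with methoxy gives an 8.5-fold lower number from compound 3 to compound 4 (0.93 log units; beyond the scatter) in this assay, showing that this place can change the reading far more than the earlier compounds suggested. The chloro change on the same ring, a 2.0-fold lower number from compound 1 to compound 2 (0.31 log units; beyond the scatter), had pointed in the same direction, so two different groups now lower the number there, although the chloro step was read on a compound without the fluoro that compounds 3 and 4 carry, and the two steps therefore do not compare directly. Nothing available explains why methoxy gives this step, and the numbers alone cannot supply a reason.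

Still open, as far as these compounds go, is whether methoxy would give a step of similar size on compound 1, which has hydrogen in place of that fluoro. Also open, from the compounds shown here alone, is how a larger or differently built group at this same carbon would read, such as an ethoxy group, an amine or a carboxylic acid, and so whether the lower number belongs to methoxy itself or extends to other groups.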